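Lipophilicity of alkylamino alcohols and diamines: next analog

The source may hold more compounds than are shown below. What is called first, only, known or untested is meant among the compounds shown, and "the series" means these compounds.

Measured so far in a physicochemical assay for lipophilicity; on this read-out higher numbers stand for higher lipophilicity and lower numbers for lower lipophilicity:
compound 1 `CCCCCCCCNCCO` gives 2.55
compound 2 `CCCCCCCCCCNCCN` gives 2.71
compound 3 `CCCCCCCCCCNCCCN` gives 2.82

Compound 3 is not separated from the other two in this assay: the step of a number 0.11 log units higher from compound 2 to compound 3 (within the scatter) is within the scatter, and the gap from compound 1 to compound 3 is of the same order and also within the scatter. The three values sit close together.

The next analog is compound 4 `CCCCCCCCCCNCCO`, which differs from compound 3 by hydroxy in place of aminomethyl on a saturated chain carbon, two bonds along the chain from an amine nitrogen. Among the compounds with values here, only one measured step touches the same position: a number 0.11 log units higher from compound 2 to compound 3 (within the scatter), which was within the scatter. Of the remaining pairs, compound 2 and compound 4 share the chain and differ only in the end group, and compound 1 carries the same end group as compound 4 on a shorter chain; for neither pair is a step available, so only the two values themselves can be set beside the result for compound 4.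

Given that the one comparable step stayed within the scatter, compound 4 is expected to stay close to compound 3 in this assay, with an estimated step of a number 0.03 log units higher from compound 3 to compound 4 (within the scatter) and no clear direction. Compound 4 is therefore estimated at 2.85, in the range 2.5 to 3.2.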

Compound 4, partition coefficient: 3.09
Beside the measured number, compound 4's estimate is 0.24 log units below it; the measured number falls inside the stated range.
By their numbers in this assay, from the lowest: compounds 1, 2, 3 and 4 (each within the scatter of the next, the first and the last beyond it).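

In this assay, within the data shown here, hydroxy in place of amino on a saturated chain carbon, two bonds along the chain from an amine nitrogen, gives a number 0.38 log units higher from compound 2 to compound 4 (beyond the scatter), the first step at this position to clear the scatter, while hydroxy in place of aminomethyl at the same place gives only a number 0.27 log units higher from compound 3 to compound 4 (within the scatter), so the end group can register on this read-out, but hydroxy is separated from amino alone. Among these compounds, the series also now holds a chain comparison with the hydroxy end group kept constant: ethyl in place of hydrogen on a saturated chain carbon, eight bonds along the chain from an amine nitrogen, gives a number 0.54 log units higher from compound 1 to compound 4 (beyond the scatter), the largest step so far and also beyond the scatter. No supporting measurement bears on the origin of either step.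

From the compounds shown here alone, whether the separation between hydroxy and amino persists on a longer chain remains open, as does the size of the chain step with an amino end group. Also open, going by these compounds, is where a methoxy or a carboxylic acid at this place would fall relative to compound 4.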